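The compounds below may be only part of what the source reports. "The series", "measured", "known", "first", "only" and "open" are said of these compounds alone.

The series shares one core. Compound 1 `Nc1cc(N)c2nc(-c3ccccc3)c(Sc3ccc(Cl)c(Cl)c3)nc2c1` and compound 2 `Nc1cc(N)c2nc(-c3ccccc3)c(Oc3ccc(F)cc3)nc2c1` are the measured pair. In a functional assay on SR cells (Homo sapiens) for inhibition, read by sulforhodamine B assay, with a stated time of 48 h (a higher number here means that more compound is tolerated, a lower number that less compound is tolerated), compound 1 reaches only a limit, < 100000 nM. In this assay compound 2 likewise reaches only a limit, < 100000 nM. The step that the two limits leave unreadable from compound 1 to compound 2 is therefore unreadable, since both values sit at the limit of < 100000 nM in this assay, at which 2 of the 2 values shown sit. Compound 3 `Nc1cc(N)c2nc(-c3ccccc3)c(Sc3ccc(F)cc3)nc2c1` carries the change ((4-fluorophenyl)sulfanyl in place of 4-fluorophenoxy on an aromatic carbon). For the measured compounds named here, no measured step bears on this exchange, so neither size nor direction can be read for this assay. Compound 3 is therefore expected to give 20000 nM, within 3000 nM to 100000 nM. The implied estimated step is a step that the limit leaves unreadable from compound 2 to compound 3, most likely again reported as a limit.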

Compound 3, concentration lethal to 50% of the cells: < 100000 nM
Compound 3 ended at the assay's limit (the forecaster's own chance of this, stated with the estimate: 60%); the middle value is on the limit's open side.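

No step among compound 1, compound 2 and compound 3 can be read in this assay, since all three values are limits: the limit of < 100000 nM in this assay, at which 3 of the 3 values shown sit.

Still open, on these data alone, is where each compound's actual value lies, and whether either exchange changes it at all.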